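Fluoro for trifluoromethoxy on the shared core

A few compounds are considered here, and "the series" means these few. Any claim that something is new, unique, unknown or untested is made for them only; others in the source may bear on it.

Measured in an in vitro ADME assay on microsomes from liver (Mus musculus) for pharmacokinetics, read by LC-MS; a higher number here means faster removal of the compound, a lower number slower removal:
- compound 1 `Cc1cccc2c1nc(C)n2-c1ccc(C(=O)NC2CC2)s1`: 66 mL/min/kg
- compound 2 `Cc1nc2ccc(OC(F)(F)F)cc2n1-c1ccc(C(=O)NC2CC2)s1`: 41 mL/min/kg

In this assay, compound 2 gives 41 mL/min/kg and compound 1 gives 66 mL/min/kg. These two values lie within the scatter of each other, so compound 2 stands level with compound 1 on clearance.

The next compound is compound 3 `Cc1nc2ccc(F)cc2n1-c1ccc(C(=O)NC2CC2)s1`, which has not yet been measured. It carries fluoro in place of trifluoromethoxy on an aromatic carbon, meta to a fused ring and para to a fused ring. The change is otherwise confined to that one place: fluoro in place of trifluoromethoxy on an aromatic carbon.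

Going by the values given here, no two measured compounds differ in one place only, so the series gives no direct guide to the size of this step. The only anchors are the two values, which sit within the scatter of each other. On that thin basis, no change beyond the scatter is expected, and neither direction is favoured with any confidence. The expected step is a 1.2-fold higher number from compound 2 to compound 3 (0.09 log units; within the scatter), an estimate that stays within the scatter. For compound 3 the estimated clearance is 50 mL/min/kg, with an expected range of 28 mL/min/kg to 85 mL/min/kg.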

Compound 3, clearance: > 72 mL/min/kg
Compound 3 gave a limit, no number; the forecaster's own chance of this, stated with the estimate: 3%; middle value at least 1.4-fold (0.15 log units) away from the limit.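

In this assay, going by these compounds alone, fluoro in place of trifluoromethoxy on this aromatic carbon, meta to a fused ring and para to a fused ring, yields the first single-place step, read as an at least 1.7-fold higher number from compound 2 to compound 3 (0.24 log units; that floor lies within the scatter), and so the series now has a direct reading at this position. Compound 3 gives a limit of the assay and not a number: the limit of > 72 mL/min/kg in this assay, at which 1 of the 3 values shown sits. The step therefore has a floor but no upper bound, and while that floor alone does not carry the change beyond the scatter, the reading offers no sign that fluoro slows removal relative to trifluoromethoxy at this position.

From the compounds shown here alone, how far compound 3 actually lies from compound 2 remains open, since the limit hides its number, and a single step cannot show whether the same change would behave alike on another part of the shared core. Also open, going by these compounds, is where other groups on this aromatic carbon, such as chloro, methoxy, trifluoromethyl or a plain hydrogen, would fall relative to trifluoromethoxy and fluoro.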